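Lengthening the Ester Side Chain by One Carbon

The source may hold more compounds than are shown below. What is called first, only, known or untested is meant among the compounds shown, and "the series" means these compounds.

Compound 1 `O=C(O)Cn1c(SCCCCOc2ccccc2)nc2ccccc21`: 1400 nM
Compound 2 `CCOC(=O)CCCSc1nc2ccccc2n1CC(=O)O`: 4410 nM

Among the measured compounds shown here, in an assay on HEK293 cells for displacement of a labelled ligand from prostaglandin D2 receptor 2 (Homo sapiens) (a lower number here means a stronger inhibitor, a higher number a weaker inhibitor), compound 2 gives the higher of the two numbers; the only measured step, a 3.2-fold higher number from compound 1 to compound 2 (0.50 log units; beyond the scatter), places compound 1 at the lower one. Compound 3 `CCOC(=O)CCCCSc1nc2ccccc2n1CC(=O)O` differs from compound 2 by (ethoxycarbonyl)methyl in place of ethoxycarbonyl on a saturated chain carbon, three bonds along the chain from a sulfur. For the measured compounds named here, no measured step alters the length of this chain; the step from compound 1 to compound 2 exchanges the end group instead, so it bears on this change only loosely. A step of no size beyond the scatter is therefore expected, a 1.1-fold lower number from compound 2 to compound 3 (0.04 log units; within the scatter). Compound 3 is estimated at 4000 nM, within a range of 1500 nM to 12000 nM.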

Compound 3, half-maximal inhibitory concentration: 2360 nM
Beside the measured number, compound 3's estimate is 1.7-fold (0.23 log units) above it, and the stated range covers the measured number.
By their numbers in this assay, from the lowest: compounds 1, 3 and 2 (each within the scatter of the next, the first and the last beyond it).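

In this assay, (ethoxycarbonyl)methyl in place of ethoxycarbonyl on a saturated chain carbon, three bonds along the chain from a sulfur, gives a 1.9-fold lower number from compound 2 to compound 3 (0.27 log units; within the scatter), so this one-carbon change cannot be told from repeat scatter. With ethoxycarbonyl in place of phenoxy, four bonds along the chain from a sulfur, the data give a 1.7-fold higher number from compound 1 to compound 3 (0.23 log units; within the scatter), so compound 3 also cannot be told apart from compound 1. No measurement shown accounts for either step. Still open, from the compounds shown here alone, is whether a longer chain, or a carboxylic acid or an amine in place of the ethoxycarbonyl, would give a step beyond the scatter.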